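The compounds below may be only part of what the source reports. "The series", "measured", "known", "first", "only" and "open" are said of these compounds alone.

Measured in a functional assay on A549 cells (Homo sapiens) for inhibition, read by CCK-8 assay, with a stated time of 72 h, tested at 2 uM; a higher number here means more inhibition of growth at the concentration tested, a lower number less inhibition of growth:
compound 1 `Cc1cc(C)cc(SCc2ccc(/C=C/C(=O)Nc3ccccc3N)cc2)c1`: 46.1%
compound 2 `CCc1ccc(SCc2ccc(C(=O)Nc3ccccc3N)cc2)cc1`: 53.6%

In this assay compound 1 stands at 46.1% and compound 2 at 53.6%, so the two lie within the scatter of each other and neither can be ranked over the other. Compound 3 `Nc1ccccc1NC(=O)/C=C/c1ccc(CSc2ccc(F)cc2)cc1` has not yet been measured. It departs from compound 1 in one place, with 4-fluorophenyl in place of 3,5-dimethylphenyl on a sulfur. Each of the two groups is one six-membered aromatic ring of carbon only, and the rest of compound 1 stays as it is. Among the measured compounds shown here, no pair of measured compounds differs in one place alone, so the data give no direct size for this change. With so little to go on, a shift beyond the scatter in this assay is not expected, and neither direction can be favoured with any confidence. The expected step of a number 1.9 percentage points higher from compound 1 to compound 3 (within the scatter) is small and stays within the scatter. For compound 3 the estimated value is 48%, with an expected range from 33% to 63%.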

Compound 3, percent growth inhibition at one concentration: 51.2%
The estimate for compound 3 lay 3.2 percentage points below the measured number; low and high end bracket the measured number.
By their numbers in this assay, from the lowest: compounds 1, 3 and 2 (each within the scatter of the next).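

In this assay, among the compounds shown here, putting 4-fluorophenyl in place of 3,5-dimethylphenyl on the sulfur gives a number 5.1 percentage points higher from compound 1 to compound 3 (within the scatter), and this is the first direct size for any single change. Here a one-ring aromatic group with 7 heavy atoms, one of them fluorine, stands in for one with 8 heavy atoms, all carbon, and the reading does not separate the two, so this pair shows no measurable dependence on which of these two groups sits on the sulfur. The result rests on one pair, and no measurement is available that could explain it or show what else may differ between the two compounds.

The compounds shown leave open whether a group of another kind on the sulfur, such as cyclohexyl, a pyridine ring or a phenyl ring carrying a carboxylic acid or an amine, would move the number beyond the scatter. They also leave open whether the same exchange would read alike on the core of compound 2.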